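Working notes on compounds 1 to 4

A few compounds are considered here, and "the series" means these few. Any claim that something is new, unique, unknown or untested is made for them only; others in the source may bear on it.

Measured so far:
- compound 1, `COC[C@H](NC1CCN(CCCc2c[nH]c3ccc(-n4cnnc4)cc23)CC1)c1ccccc1`: in an assay on CHO cells for agonist activity at 5-hydroxytryptamine receptor 1D (Homo sapiens), read by GTPgammaS binding (a higher number here means that more compound is needed for the effect, a lower number that less compound is needed), compound 1 gives 0.9 nM
- compound 2, `c1ccc(C2CCCCN2C2CCN(CCCc3c[nH]c4ccc(-n5cnnc5)cc34)CC2)cc1`: in this assay compound 2 gives 4.7 nM
- compound 3, `OC[C@H](NC1CCN(CCCc2c[nH]c3ccc(-n4ccnc4)cc23)CC1)c1ccccc1`: in this assay compound 3 gives 0.8 nM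

On these three numbers compound 1 holds the second highest; compound 3 sits within the scatter of it, while compound 2 stands beyond the scatter with the higher number of the set. For the measured compounds named here, no pair of measured compounds differs in a single place, so no single-point step is available as a reference.

Compound 4, `c1ccc2c(c1)CCC2NCC1CCN(CCCc2c[nH]c3ccc(-n4cnnc4)cc23)CC1`, is not yet measured. It differs from compound 1 in one place: ((2,3-dihydro-1H-inden-1-yl)amino)methyl in place of (2-methoxy-1-phenylethyl)amino on a saturated ring carbon. The amine now hangs from the saturated ring carbon through a methyl link and carries the 2,3-dihydro-1H-inden-1-yl group instead of the 2-methoxy-1-phenylethyl group.

Going by the values given here, with no measured step to lean on, the expectation is a small loss, at or just beyond the scatter, as a 3.3-fold higher number from compound 1 to compound 4 (0.52 log units; beyond the scatter). Compound 4 is estimated at 3 nM, with a range from 0.8 nM to 12 nM.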

Compound 4, half-maximal effective concentration: 1.3 nM
The estimate for compound 4 lay 2.3-fold (0.36 log units) above the measured number, within the range that was stated.
By their numbers in this assay, from the lowest: compounds 3, 1 and 4 (each within the scatter of the next); then compound 2.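

In this assay, ((2,3-dihydro-1H-inden-1-yl)amino)methyl in place of (2-methoxy-1-phenylethyl)amino on the saturated ring carbon gives a 1.4-fold higher number from compound 1 to compound 4 (0.16 log units; within the scatter), the first single-place step available in the series. This position therefore accepts a substantial change in this one case: the oxygen and the defined stereocentre of the leaving group go, a five-membered non-aromatic ring of carbon only and a methyl link enter, and the two numbers remain within the scatter of each other. No measurement at hand accounts for this result.

This single step cannot separate the contribution of the methyl link from that of the five-membered ring or the loss of the oxygen. Going by these compounds, whether a carboxylic acid or a longer chain at this ring carbon would also remain within the scatter of compound 1 stays open.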